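Cyano in Place of Hydrogen on a Benzamide Ring

This account rests on a few compounds, and the source may have more. Where it says the series, first, only, none or still open, it means among the compounds named here.

Measured compounds:
Compound 1 `CCOC(=O)c1sc(-c2cccc(NC(=O)c3ccc(C(F)(F)F)cc3)c2)nc1Nc1ccc(N2CCN(C)CC2)cc1` — in a functional assay on Ramos cells (Homo sapiens) for antiproliferative activity, read by CCK-8 assay, with a stated time of 72 h (a higher number here means a weaker inhibitor, a lower number a stronger inhibitor), compound 1 is recorded as "not determined" (no result reported).
Compound 2 `CCOC(=O)c1sc(-c2cccc(NC(=O)c3ccccc3)c2)nc1Nc1ccc(N2CCN(C)CC2)cc1` — 24800 nM.

Compound 1 and compound 2 share a core; for compound 1 no number was reported, so compound 2 stands alone as the only measured entry. In this assay compound 2 gives 24800 nM, a weak result. Compound 3 `CCOC(=O)c1sc(-c2cccc(NC(=O)c3ccc(C#N)cc3)c2)nc1Nc1ccc(N2CCN(C)CC2)cc1` differs from compound 2 in one spot: cyano in place of hydrogen on an aromatic carbon. Among the measured compounds shown here, no step between two measured compounds is available, so there is nothing to lean on beyond the single value of compound 2. The expectation is a step from compound 2 to compound 3 of about a 1.7-fold lower number from compound 2 to compound 3 (0.22 log units; within the scatter), small and not clearly beyond the usual scatter, with only a slight lean toward a stronger inhibitor. Compound 3 is therefore estimated at 15000 nM, with a range from 5000 nM to 50000 nM.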

Compound 3, half-maximal inhibitory concentration: 4280 nM
The estimate for compound 3 lay 3.5-fold (0.54 log units) above the measured number; the whole stated range lies above it.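

In this assay, replacing phenyl with 4-cyanophenyl gives a 5.8-fold lower number from compound 2 to compound 3 (0.76 log units; beyond the scatter), which shows that this aromatic carbon, para to a large group, is a place where a single added group can make a stronger inhibitor. This is one step at one position, so it establishes that the position responds to this change but not a general trend. Nothing among the available data explains why the number falls.

Steps involving compound 1, which carries trifluoromethyl at this carbon, cannot be read, as its entry is "not determined" (no result reported), so cyano has no measured neighbour for comparison at this position. On these data alone, it remains open whether an amine, a carboxylic acid or a methoxy group on this carbon would shift the number in the same direction, or by as much, as cyano.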